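Acyl group swaps on the shared pyrrolidine amide core

This account rests on a few compounds, and the source may have more. Where it says the series, first, only, none or still open, it means among the compounds named here.

Measured so far in an assay on CHO cells for displacement of a labelled ligand from Substance-P receptor (Homo sapiens); on this read-out higher numbers stand for weaker inhibition and lower numbers for stronger inhibition:
- compound 1, `CC(C)C(=O)N1C[C@@H](O[C@H](C)c2cc(C(F)(F)F)cc(C(F)(F)F)c2)[C@H](c2ccc(F)cc2)C1`, gives 0.15 nM
- compound 2, `CC(=O)N1CCC(C(=O)N2C[C@@H](O[C@H](C)c3cc(C(F)(F)F)cc(C(F)(F)F)c3)[C@H](c3ccc(F)cc3)C2)CC1`, gives 0.07 nM
- compound 3, `C[C@@H](O[C@@H]1CN(C(=O)[C@@H]2CCC(=O)N2C)C[C@H]1c1ccc(F)cc1)c1cc(C(F)(F)F)cc(C(F)(F)F)c1`, gives 0.12 nM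

Compound 3 holds the second highest of the three numbers. Its gap to compound 1 is within the scatter, and so is its gap to compound 2, so no order between compound 3 and either of the others can be drawn from these numbers. Among the compounds with values here, the only step beyond the scatter is a 2.1-fold lower number from compound 1 to compound 2 (0.33 log units; beyond the scatter), and that one is modest.

Compound 4, `C[C@@H](O[C@@H]1CN(C(=O)[C@@H]2COC(=O)N2)C[C@H]1c1ccc(F)cc1)c1cc(C(F)(F)F)cc(C(F)(F)F)c1`, differs from compound 3 by 2-oxo-1,3-oxazolidin-4-yl in place of 1-methyl-5-oxopyrrolidin-2-yl on a carbonyl carbon.

All three measured steps change the group on the same carbonyl carbon, and they bear on this change: a 2.1-fold lower number from compound 1 to compound 2 (0.33 log units; beyond the scatter), a 1.3-fold lower number from compound 1 to compound 3 (0.10 log units; within the scatter) and a 1.7-fold higher number from compound 2 to compound 3 (0.23 log units; within the scatter). Two of these lie within the scatter and the third is modest, so exchanges at this position have moved this assay little in either direction. On that basis no step beyond the scatter is expected from compound 3 to compound 4; the estimate leans slightly towards a higher number, as a 1.7-fold higher number from compound 3 to compound 4 (0.22 log units; within the scatter), since the group entering resembles none of the three measured ones.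

Compound 4 is therefore estimated at 0.2 nM in this assay, with a range from 0.07 nM to 0.6 nM.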

Compound 4, half-maximal inhibitory concentration: 0.34 nM
The estimate for compound 4 lay 1.7-fold (0.23 log units) below the measured number; the range from low to high includes it.
By their numbers in this assay, from the lowest: compounds 2, 3 and 1 (each within the scatter of the next, the first and the last beyond it); then compound 4.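

In this assay, the group on this carbonyl carbon can now be seen to matter beyond the scatter in the direction of a higher number: a 2.8-fold higher number from compound 3 to compound 4 (0.45 log units; beyond the scatter), a 4.9-fold higher number from compound 2 to compound 4 (0.69 log units; beyond the scatter) and a 2.3-fold higher number from compound 1 to compound 4 (0.36 log units; beyond the scatter), each modest, leave compound 4 as the weakest of the four. The change from 1-methyl-5-oxopyrrolidin-2-yl to 2-oxo-1,3-oxazolidin-4-yl keeps a five-membered non-aromatic ring, with 6 heavy atoms entering for 7, yet it is not neutral in this assay, and the entering group is the only one here with a hydrogen-bond donor. No measurement available here connects the higher number of compound 4 to any feature of the entering group.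

Compound 4 alone cannot separate the effect of the amide hydrogen from that of the ring oxygen, so the same 2-oxo-1,3-oxazolidin-4-yl ring with a methyl on its nitrogen would be the telling comparison. Going by these compounds, how this assay responds to an amine or a carboxylic acid on this carbonyl carbon also remains open.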